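Benzofuranyl for naphthyl at the limit of the cytotoxicity read-out

The source may report more compounds than this note shows. Statements on the series, on what has been measured and on what is new or still open speak of the compounds shown alone.

In a functional assay on HL-60 cells (Homo sapiens) for cytotoxicity, read by XTT assay, with a stated time of 3 days (on this read-out higher numbers stand for weaker inhibition and lower numbers for stronger inhibition), compound 1 (`C[C@@]1(O)[C@H](O)[C@@H](CO)O[C@H]1n1cc(I)c2c(N)ncnc21`) gives > 10000 nM as a limit of the assay, not a number. Compound 2 (`C[C@@]1(O)[C@H](O)[C@@H](CO)O[C@H]1n1cc(-c2ccc3ccccc3c2)c2c(N)ncnc21`) gives > 10000 nM as a limit too, so it has no number of its own. Among the measured compounds shown here, the only measured step, a step that the two limits leave unreadable from compound 1 to compound 2, offers no size to carry forward. For the measured compounds named here, the series so far comes down to the limit of > 10000 nM in this assay, at which 2 of the 2 values shown sit, and nothing more. Compound 3 (`C[C@@]1(O)[C@H](O)[C@@H](CO)O[C@H]1n1cc(-c2cc3ccccc3o2)c2c(N)ncnc21`) differs from compound 2 as follows: 1-benzofuran-2-yl in place of naphthalen-2-yl on an aromatic carbon, with 1-benzofuran-2-yl in place of naphthalen-2-yl on an aromatic carbon. Going by the values given here, no step of readable size or direction is therefore expected in this assay here. The estimated step that the limit leaves unreadable from compound 2 to compound 3 is only nominal. Compound 3 is estimated at 15000 nM with an expected range from 5000 nM to 40000 nM and will most likely be reported as a limit again.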

Compound 3, half-maximal inhibitory concentration: > 10000 nM
Compound 3 was reported as a limit; the forecaster's own chance of this, stated with the estimate: 85%; the middle value is on the limit's open side.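

In this assay compound 3 gives > 10000 nM, a limit and not a number. Its steps from compound 1 and from compound 2 cannot be read. The compounds shown leave open whether any group at this place on the shared core gives a measurable value in this assay.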